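This account rests on a few compounds, and the source may have more. Where it says the series, first, only, none or still open, it means among the compounds named here.

Measured so far in a functional assay on CCRF-CEM cells (Homo sapiens) for antiproliferative activity, read by MTT assay, with a stated time of 48 h, tested at 25 uM; a higher number here means a weaker effect of the compound at the concentration tested, a lower number a stronger effect:
- compound 1 `OC(CCn1nc2c(Br)c(Br)c(Br)c(Br)c2n1)c1ccc(Br)cc1` gives 69%
- compound 2 `CC(O)CCn1nc2c(Br)c(Br)c(Br)c(Br)c2n1` gives 86%

Compound 2 stands highest of the two numbers in this assay; its nearest neighbour is compound 1, and the step of a number 17 percentage points higher from compound 1 to compound 2 (beyond the scatter) lies beyond the scatter.

Compound 3 `OC(CCn1nc2c(Br)c(Br)c(Br)c(Br)c2n1)c1cccc(Br)c1` remains to be measured in this assay. It differs from compound 2 by 3-bromophenyl in place of methyl on a saturated chain carbon bound to an oxygen on a saturated carbon and a saturated chain carbon. Among the measured compounds shown here, the only measured step that bears on this is a number 17 percentage points higher from compound 1 to compound 2 (beyond the scatter), which runs in the opposite direction: the aryl group was exchanged for methyl there, and the number rose by a modest amount. For the measured compounds named here, putting a bromophenyl back in place of the methyl is therefore expected to lower the number by a step of similar size, the bromine position being the one point of difference from compound 1, for which no step is available.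

For compound 3 the expected value in this assay is 70%, with a range from 55% to 85%, meaning an estimated step of a number 16 percentage points lower from compound 2 to compound 3 (beyond the scatter).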

Compound 3, a percentage reported as activity, at one concentration (the size of the read-out at that concentration, not a potency): 54%
The estimate for compound 3 lay 16 percentage points above the measured number; measured number outside the range, below it.
By their numbers in this assay, from the lowest: compound 3; then compound 1; then compound 2.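

In this assay, exchanging methyl for a bromophenyl group at this saturated chain carbon does not act as one fixed increment, as the change to 3-bromophenyl gives a larger step (a number 32 percentage points lower from compound 2 to compound 3 (beyond the scatter)). The location of the bromine on the phenyl ring also counts, which compound 1 and compound 2 alone could not show: 3-bromophenyl in place of 4-bromophenyl gives a step of its own (a number 15 percentage points lower from compound 1 to compound 3 (beyond the scatter)). No measurement at hand accounts for either step.

On these data alone, whether an unsubstituted phenyl, an amine or a carboxylic acid at this carbon would follow the same direction remains open, as does the effect of a longer chain between the core and this carbon. With a read-out at a single concentration, the potency of these compounds also remains open.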